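Methylated pyrazole in place of the free pyrazole

This account rests on a few compounds, and the source may have more. Where it says the series, first, only, none or still open, it means among the compounds named here.

Measured so far in a functional assay on CHO cells for agonist activity at Alpha-1D adrenergic receptor (Homo sapiens), read by FLIPR and calcium flux; on this read-out higher numbers stand for an effect only at larger amounts of compound and lower numbers for an effect already at smaller amounts:
- compound 1 `c1cc(-c2ccn[nH]2)c2c(c1)C(c1ncc[nH]1)CC2` gives 336 nM
- compound 2 `COc1cccc2c1CCC2c1ncc[nH]1` gives > 10000 nM, a limit of the assay
- compound 3 `CS(=O)(=O)Nc1c(Cl)ccc2c1CCCC2c1ncc[nH]1` gives > 10000 nM, a limit of the assay

Compound 1 is thus the only one of the three that yields a number at all; the other two sit at the limit of > 10000 nM in this assay, at which 2 of the 3 values shown sit. The unmeasured compound 4 `Cn1cc(-c2cccc3c2CCC3c2ncc[nH]2)cn1` differs from compound 1 in one place: 1-methyl-1H-pyrazol-4-yl in place of 1H-pyrazol-5-yl on an aromatic carbon. The ring that leaves carries a hydrogen-bond donor, the ring that enters carries none.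

For the measured compounds named here, only one measured step touches the same position: an at least 29-fold higher number from compound 1 to compound 2 (1.47 log units; beyond the scatter), where the whole pyrazole ring was exchanged for a methoxy group and the activity fell from a clear number to a limit. Compound 4 keeps a pyrazole ring on that carbon, so the change is less drastic than in that step, but the donor that compound 1 has is gone. The expectation for this assay is therefore a weakening of some size, with a real chance that compound 4 reaches only a limit. Compound 4 is estimated at 2000 nM, with a range from 400 nM to 10000 nM, which means an expected step of a 6.0-fold higher number from compound 1 to compound 4 (0.77 log units; beyond the scatter).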

Compound 4, half-maximal effective concentration: > 10000 nM
Compound 4 ended at the assay's limit (the forecaster's own chance of this, stated with the estimate: 35%); middle value at least 5.0-fold (0.69 log units) away from the limit.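

In this assay, exchanging one pyrazole ring for the other gives an at least 29-fold higher number from compound 1 to compound 4 (1.47 log units; beyond the scatter), so having a five-membered aromatic ring with two nitrogens on this aromatic carbon does not by itself retain a measurable effect, as the methoxy step alone could not show. Compound 4 gives > 10000 nM, which is a limit of the assay. The step from compound 2 to compound 4 cannot be read, and compound 1, with its 1H-pyrazol-5-yl group, remains the only compound shown that gives a number: the limit of > 10000 nM in this assay, at which 3 of the 4 values shown sit.

The change from compound 1 to compound 4 alters several things at once: the hydrogen-bond donor is lost, a methyl group is added, and the ring is attached through a different carbon, so the compounds shown cannot say which of these matters. A 1H-pyrazol-4-yl or a 1-methyl-1H-pyrazol-5-yl group on this carbon would help separate these changes, while an amine there would test whether any ring is needed at all.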